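The compounds below may be only part of what the source reports. "The series", "measured", "known", "first", "only" and "open" are said of these compounds alone.

In a functional assay on HCT-116 cells (Homo sapiens) for cytotoxicity, read by MTT assay, with a stated time of 72 h (a higher number here means a weaker inhibitor, a lower number a stronger inhibitor), compound 2 `COc1ccc(NC(=O)Nc2ccc(C(=O)NO)cc2)cc1` gives 22300 nM and compound 3 `O=C(Nc1ccc(C(=O)NO)cc1)Nc1ccc([N+](=O)[O-])cc1` gives 28400 nM. The step of a 1.3-fold higher number from compound 2 to compound 3 (0.11 log units; within the scatter) lies within the scatter, so these two cannot be told apart. Compound 1 `O=C(Nc1ccc(Cl)cc1)Nc1ccc(C(=O)NO)cc1` reaches only a limit of the assay, > 50000 nM. Compound 4 `COc1ccc(NC(=O)Nc2ccc(CCC(=O)NO)cc2)cc1` alters compound 2 in a new place: 2-(hydroxycarbamoyl)ethyl in place of hydroxycarbamoyl on an aromatic carbon. It carries 2-(hydroxycarbamoyl)ethyl in place of hydroxycarbamoyl on an aromatic carbon. The measured steps, such as an at least 2.2-fold lower number from compound 1 to compound 2 (0.35 log units; beyond the scatter), only exchange chloro, methoxy and nitro, so none of them tests this change and they offer just a loose guide to size. A modest move toward a lower number is expected, namely a 2.5-fold lower number from compound 2 to compound 4 (0.39 log units; beyond the scatter). In this assay the estimated value for compound 4 is 9000 nM, with an expected range of 1500 nM to 40000 nM.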

Compound 4, half-maximal inhibitory concentration: 31000 nM
The estimate for compound 4 lay 3.4-fold (0.54 log units) below the measured number; low and high end bracket the measured number.
By their numbers in this assay, from the lowest: compounds 2, 3 and 4 (each within the scatter of the next). At a limit, above all of these: compound 1.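

In this assay, placing 2-(hydroxycarbamoyl)ethyl in place of hydroxycarbamoyl on the aromatic carbon gives a 1.4-fold higher number from compound 2 to compound 4 (0.14 log units; within the scatter). The earlier steps shown here only exchanged chloro, methoxy and nitro elsewhere, whereas this one shows that the added chain at this position leaves no difference that can be told from the scatter. Only compound 1 stands at a limit: the limit of > 50000 nM in this assay, at which 1 of the 4 values shown sits.

Going by these compounds, it remains open whether a longer chain or a carboxylic acid at this position would shift the number. On these data alone, it is also open whether the same chain would behave alike with chloro or nitro in place of methoxy.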